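Phenoxy in Place of Benzyl: An Unmeasured Analogue

This account rests on a few compounds, and the source may have more. Where it says the series, first, only, none or still open, it means among the compounds named here.

Compound 1 `CCOC(=O)c1[nH]c2cc(Cl)ccc2c1/C=N/NC(=O)CCc1ccccc1`: > 10000 nM
Compound 2 `CCOC(=O)c1[nH]c2cc(Cl)ccc2c1/C=N/NC(=O)COc1cccc2ccccc12`: > 10000 nM

In an assay for inhibition of Polyunsaturated fatty acid lipoxygenase ALOX15 (Homo sapiens), with a stated time of 8 min (on this read-out higher numbers stand for weaker inhibition and lower numbers for stronger inhibition), compound 1 gives only a limit, > 10000 nM, and not a number. Compound 2 likewise reaches only a limit in this assay, > 10000 nM. Both values sit at the limit of > 10000 nM in this assay, at which 2 of the 2 values shown sit, so compound 1 stands at the edge of what this assay resolves. Compound 3 `CCOC(=O)c1[nH]c2cc(Cl)ccc2c1/C=N/NC(=O)COc1ccccc1` differs from compound 1 in one place: phenoxy in place of benzyl on a saturated chain carbon bound to a carbonyl carbon. Within the data shown here, no measured step in this assay speaks to such a change; the expected step is none beyond the scatter, so a step that the limit leaves unreadable from compound 1 to compound 3 is the estimate. Compound 3 is therefore expected at 15000 nM, within 5000 nM to 60000 nM.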

Compound 3, half-maximal inhibitory concentration: > 10000 nM
Compound 3 was reported as a limit (the forecaster's own chance of this, stated with the estimate: 85%); the middle value is on the limit's open side.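

In this assay, among these compounds, compound 3 also gives only a limit, so no step between compound 1, compound 2 and compound 3 can be read: the limit of > 10000 nM in this assay, at which 3 of the 3 values shown sit. The compounds shown leave open whether phenoxy in place of benzyl alters inhibition at all.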